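The source may hold more compounds than are shown below. What is called first, only, known or untested is meant among the compounds shown, and "the series" means these compounds.

Working notes on the series, read in an ADME assay on J774 cells (Mus musculus) for cytotoxicity, read by MTT assay, with a stated time of 48 h, tested at 50 ug/mL; a lower number here means a stronger effect, a higher number a weaker effect of the compound at the concentration tested:
compound 1 `O=C(N/N=C/c1ccccc1Cl)c1cnccn1` — 70%
compound 2 `O=C(N/N=C/c1cccc(Cl)c1)c1cnccn1` — 100%
compound 3 `COc1ccc(/C=N/NC(=O)c2cnccn2)cc1` — 74%

Among these three numbers compound 1 stands lowest. Compound 3 is its nearest neighbour, higher by an amount that lies within the scatter, so no order is read between the two. Compound 2 lies furthest off, higher by an amount beyond the scatter, so of that pair compound 2 shows the weaker effect. Compound 4 `O=C(N/N=C/c1ccccc1O)c1cnccn1` has not yet been measured in this assay. Relative to compound 1 it differs as follows: hydroxy in place of chloro on an aromatic carbon. Among the compounds with values here, no step between two measured compounds isolates this change. The expected step of a number 10 percentage points higher from compound 1 to compound 4 (within the scatter) is small, towards a higher number, and may fall within the scatter. Compound 4 is estimated at 80% in this assay, with a range from 60% to 100%.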

Compound 4, a percentage reported as activity, at one concentration (the size of the read-out at that concentration, not a potency): 1%
Compound 4: middle estimate off by 79 percentage points, on the high side; the measured number lies below the stated range.
By their numbers in this assay, from the lowest: compound 4; then compounds 1 and 3 (each within the scatter of the next); then compound 2.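

In this assay, within the data shown here, hydroxy in place of chloro on an aromatic carbon ortho to a large group gives a number 69 percentage points lower from compound 1 to compound 4 (beyond the scatter), so the number depends strongly on what sits at this place, which the earlier compounds, joined by no readable step, could not show. The change swaps one heavy atom for one other and brings in a hydrogen-bond donor and a hydrogen-bond acceptor. No measurement at hand bears on the reason for so large a step. Going by these compounds, whether an amine or a carboxylic acid at this place gives a step of similar size stays open. So does whether the hydroxy gives the same step elsewhere on the ring.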